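The source may hold more compounds than are shown below. What is called first, only, known or untested is meant among the compounds shown, and "the series" means these compounds.

Compound 2 `CC(C)(C)C1=NN(c2ccc(Cl)cc2Cl)C(c2ccc(O)cc2)C1` stands highest of the two compounds measured in an assay on isolated protein for inhibition of protein kinase C zeta type (Homo sapiens), with a stated time of 4 min, tested at 62.5 uM; a lower number here means less inhibition, a higher number more inhibition at the concentration tested (going by the name of the read-out); compound 2 gives 71%, while compound 1 `CC(C)(C)C1=NN(c2ccccc2Cl)C(c2ccc(O)cc2)C1` gives 57.1% in this assay. Among the measured compounds shown here, the only measured step, a number 13.9 percentage points higher from compound 1 to compound 2 (beyond the scatter), shows that a chloro on the ring attached to the ring nitrogen raised inhibition. Compound 3 `CC(C)(C)C1=NN(c2ccc(F)cc2F)C(c2ccc(O)cc2)C1` differs from compound 2 by 2,4-difluorophenyl in place of 2,4-dichlorophenyl on an amine nitrogen in a ring. For the measured compounds named here, no measured step exchanges chlorine for fluorine, so that step is only a loose guide. Compound 3 is therefore expected to sit somewhat lower than compound 2, a step of a number 16 percentage points lower from compound 2 to compound 3 (beyond the scatter). Compound 3 is estimated at 55%, between 35% and 75%.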

Compound 3, a percentage reported as inhibition, at one concentration (the size of the read-out at that concentration, not a potency): 68%
For compound 3 the middle estimate is 13 percentage points below the measured one; low and high end bracket the measured number.
By their numbers in this assay, from the lowest: compound 1; then compounds 3 and 2 (each within the scatter of the next).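

In this assay, 2,4-difluorophenyl in place of 2,4-dichlorophenyl on the amine nitrogen in the ring gives a number 3 percentage points lower from compound 2 to compound 3 (within the scatter), so this exchange of both halogens leaves the read-out within the scatter, something the earlier pair could not show. Set against the 2-chlorophenyl group, the 2,4-difluorophenyl group gives a number 10.9 percentage points higher from compound 1 to compound 3 (beyond the scatter), so the gain over compound 1 is not confined to the dichloro compound. No evidence here explains these results.

From the compounds shown here alone, whether a methoxy or trifluoromethyl group on this ring would read the same stays open. So does the outcome with a plain unsubstituted phenyl group at this position.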